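The source may report more compounds than this note shows. Statements on the series, on what has been measured and on what is new or still open speak of the compounds shown alone.

Measured in an assay on brain for displacement of a labelled ligand from D(3) dopamine receptor (Rattus norvegicus); on this read-out higher numbers stand for weaker inhibition and lower numbers for stronger inhibition:
compound 1 `CCCN(CC[C@H]1CC[C@H](NC(=O)/C=C/c2cccc(F)c2)CC1)[C@H]1CCc2nc(N)sc2C1` gives 9.9 nM
compound 2 `CCCN(CC[C@H]1CC[C@H](NC(=O)/C=C/c2ccccc2Cl)CC1)[C@H]1CCc2nc(N)sc2C1` gives 1.2 nM
compound 3 `CCCN(CC[C@H]1CC[C@H](NC(=O)c2cccc3ncccc23)CC1)[C@H]1CCc2nc(N)sc2C1` gives 1.6 nM

Compound 3 stands second highest of the three numbers in this assay: a 6.2-fold lower number from compound 1 to compound 3 (0.79 log units; beyond the scatter), whereas a 1.3-fold higher number from compound 2 to compound 3 (0.12 log units; within the scatter).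

Compound 4 `CCCN(CC[C@H]1CC[C@H](NC(=O)c2cccc(-n3cncn3)c2)CC1)[C@H]1CCc2nc(N)sc2C1` differs from compound 3 by 3-(1H-1,2,4-triazol-1-yl)phenyl in place of quinolin-5-yl on a carbonyl carbon. Steps that bear on this change: an 8.3-fold lower number from compound 1 to compound 2 (0.92 log units; beyond the scatter) and a 6.2-fold lower number from compound 1 to compound 3 (0.79 log units; beyond the scatter) show that exchanging the group on the carbonyl can move the number beyond the scatter, while a 1.3-fold higher number from compound 2 to compound 3 (0.12 log units; within the scatter) shows it need not. Among the compounds with values here, no measured step exchanges one aryl bound directly to the carbonyl for another, so the direction is open. A small rise in this assay is expected for compound 4, which is estimated at 3.5 nM with a range from 0.9 nM to 14 nM; this estimate means a 2.2-fold higher number from compound 3 to compound 4 (0.34 log units; beyond the scatter).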

Compound 4, inhibition constant: 3 nM
For compound 4 the middle estimate is 1.2-fold (0.07 log units) above the measured one; the range from low to high includes it.
By their numbers in this assay, from the lowest: compounds 2, 3 and 4 (each within the scatter of the next, the first and the last beyond it); then compound 1.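

In this assay, within the data shown here, the exchange of one aryl bound directly to the carbonyl for another gives a 1.9-fold higher number from compound 3 to compound 4 (0.27 log units; within the scatter) and so stays within the scatter, which the earlier steps, each involving an ethenyl chain, could not show. Against those ethenyl amides the triazolylphenyl group falls on both sides, with a 3.3-fold lower number from compound 1 to compound 4 (0.52 log units; beyond the scatter) but a 2.5-fold higher number from compound 2 to compound 4 (0.40 log units; beyond the scatter) as steps beyond the scatter. No measurement at hand gives a reason for these steps.

Going by these compounds, what the 1H-1,2,4-triazol-1-yl group itself contributes stays open. A plain phenyl on the carbonyl, or an amine or a carboxylic acid in the triazole's place, would be needed to separate it from the phenyl ring.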